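Swapping a Thiophene for a Furan in Compound 1

This account rests on a few compounds, and the source may have more. Where it says the series, first, only, none or still open, it means among the compounds named here.

The shared core of this small set is seen in compound 1 `O=C(Nc1ccc(Cl)cc1)C1CCCN(C(=O)c2cccc(-c3cccs3)c2)C1`. In a functional assay on PC-3 cells (Homo sapiens), with a stated time of 24 h, tested at 10 uM (on this read-out lower numbers stand for less inhibition and higher numbers for more inhibition at the one concentration tested (going by the name of the read-out)), compound 1 gives 70%, the highest of the two numbers in hand. Compound 3 `O=C(Nc1ccc(Cl)cc1)C1CCCN(C(=O)c2cc(C(F)(F)F)cc(C(F)(F)F)c2)C1` gives 22% in this assay, a number that sits well beyond the usual scatter from that of compound 1. Compound 2 `O=C(Nc1cccc(S(=O)(=O)N2CCCC2)c1)C1CCCN(C(=O)c2cc(C(F)(F)F)cc(C(F)(F)F)c2)C1` is recorded only at a limit of this assay, < 30%, so no number is known for it. One of the three values thus stands at the limit of < 30% in this assay, at which 1 of the 3 values shown sits. No pair of these compounds differs in a single place, so no measured step is available to guide the next change.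

Compound 4 `O=C(Nc1ccc(Cl)cc1)C1CCCN(C(=O)c2cccc(-c3ccco3)c2)C1` has not yet been measured. Its difference from compound 1 is furan-2-yl in place of thiophen-2-yl on an aromatic carbon. Within the data shown here, both groups are five-membered aromatic rings with one hetero atom and one hydrogen-bond acceptor, and nothing among the measured compounds bears directly on such an exchange. The step of a number 10 percentage points lower from compound 1 to compound 4 (within the scatter) is therefore estimated to stay within the usual scatter, leaning only slightly downward. Compound 4 is expected to give about 60% in this assay, with a range from 35% to 85%.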

Compound 4, a percentage reported as inhibition, at one concentration (the size of the read-out at that concentration, not a potency) in the PC-3 assay: 70%
Beside the measured number, compound 4's estimate is 10 percentage points below it; the measured number falls inside the stated range.
By their numbers in the PC-3 assay, from the lowest: compound 3; then compounds 1 and 4 (each within the scatter of the next).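

Among these compounds, in the PC-3 assay, furan-2-yl in place of thiophen-2-yl on an aromatic carbon gives no change at the digits printed from compound 1 to compound 4 (within the scatter), the first step in this set that changes one place only. The number seen for compound 1 therefore does not depend on thiophen-2-yl alone, since another five-membered aromatic ring with one hetero atom serves equally well at this place on the six-membered aromatic ring, meta to a large group. In a physicochemical assay for solubility, measured as kinetic solubility (on this read-out lower numbers stand for lower solubility and higher numbers for higher solubility), compound 1 gives 1.36 ug/mL and compound 4 gives 3.09 ug/mL. The same exchange does register in the physicochemical assay, so the two read-outs part ways here, with inhibition holding level while solubility moves modestly upward, although both compounds remain at low values on that scale: the measured solubility of compound 1, 1.36 ug/mL, and of compound 4, 3.09 ug/mL, a 2.3-fold higher number (0.36 log units; beyond the scatter)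

In the PC-3 assay compound 2 stands at a limit, < 30%, and so offers no number to set against the others. On these data alone, it also stays open how a morpholine or a carboxylic acid at this same place would read in the PC-3 assay and in the physicochemical assay, and whether a group of that kind could lift solubility further without losing the inhibition shared by compound 1 and compound 4.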